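Cytotoxicity of benzyl ether analogues and a nitro variant

This account rests on a few compounds, and the source may have more. Where it says the series, first, only, none or still open, it means among the compounds named here.

Measured in an ADME assay on Huh-5-2 cells (Homo sapiens) for cytotoxicity, read by WST assay, with a stated time of 3 days; a lower number here means that less compound is tolerated, a higher number that more compound is tolerated:
compound 1 `O=c1c(OCc2ccccc2Cl)c(-c2ccccc2)oc2cc(O)cc(O)c12`: > 100000 nM, a limit of the assay
compound 2 `Cc1ccccc1COc1c(-c2ccccc2)oc2cc(O)cc(O)c2c1=O`: 55000 nM
compound 3 `N#Cc1cccc(COc2c(-c3ccccc3)oc3cc(O)cc(O)c3c2=O)c1`: 21000 nM

Compound 3 has the lowest of the two numbers, with compound 2 nearest a 2.6-fold lower number from compound 2 to compound 3 (0.42 log units; beyond the scatter). Compound 1 sits at a limit (the limit of > 100000 nM in this assay, at which 1 of the 3 values shown sits), so an at least 4.7-fold lower number from compound 1 to compound 3 (0.67 log units; beyond the scatter) is only a floor. Compound 4 `O=c1c(OCc2ccc([N+](=O)[O-])cc2)c(-c2ccccc2)oc2cc(O)cc(O)c12` differs from compound 3 by 4-nitrophenyl in place of 3-cyanophenyl on a saturated chain carbon bound to an oxygen on an aromatic ring. The two steps that bear on this place, an at least 4.7-fold lower number from compound 1 to compound 3 (0.67 log units; beyond the scatter) and a 2.6-fold lower number from compound 2 to compound 3 (0.42 log units; beyond the scatter), both moved the number down when the aryl group on that carbon changed, but neither involved a nitrophenyl. A further small lowering is expected, a 1.4-fold lower number from compound 3 to compound 4 (0.15 log units; within the scatter), possibly within the scatter. Compound 4 is estimated at 15000 nM, between 5000 nM and 45000 nM.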

Compound 4, half-maximal cytotoxic concentration: 40000 nM
The estimate for compound 4 lay 2.7-fold (0.43 log units) below the measured number; the measured number falls inside the stated range.
By their numbers in this assay, from the lowest: compounds 3, 4 and 2 (each within the scatter of the next, the first and the last beyond it). At a limit, above all of these: compound 1.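

In this assay the 4-nitrophenyl group on this saturated chain carbon cannot be told apart from the 3-cyanophenyl group (a 1.9-fold higher number from compound 3 to compound 4 (0.28 log units; within the scatter)) or from the 2-methylphenyl group (a 1.4-fold lower number from compound 2 to compound 4 (0.14 log units; within the scatter)), although those two groups were separated beyond the scatter. Within the data shown here, only the step from the 2-chlorophenyl group lies beyond the scatter (an at least 2.5-fold lower number from compound 1 to compound 4 (0.39 log units; beyond the scatter)), and that step is a floor.

The compounds shown leave open whether a phenyl group carrying an amine or a carboxylic acid would stay in this range. How far compound 1 truly lies from the others also stays open, as its value is a limit: the limit of > 100000 nM in this assay, at which 1 of the 4 values shown sits.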